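The source may hold more compounds than are shown below. What is called first, only, known or untested is meant among the compounds shown, and "the series" means these compounds.

Measured compounds:
Compound 1, `N#Cc1ccc(N2CCN(C(=S)SCc3ccc(C(=O)Nc4ccccc4N)cc3)CC2)cc1`: 62.9%
Compound 2, `CC1CCN(C(=S)SCc2ccc(C(=O)Nc3ccccc3N)cc2)CC1`: 87.4%

Going by the values given here, in a functional assay on A-375 cells (Homo sapiens) for antiproliferative activity, read by CCK-8 assay, with a stated time of 72 h, tested at 8 uM (on this read-out lower numbers stand for a weaker effect and higher numbers for a stronger effect at the one concentration tested), compound 2 gives 87.4%, the higher of the two numbers known so far, while compound 1 gives 62.9%, a gap beyond the usual scatter of repeated measurements. Compound 3, `CN1CCN(C(=S)SCc2ccc(C(=O)Nc3ccccc3N)cc2)CC1`, has not yet been measured in this assay. It differs from compound 2 in one place: 4-methylpiperazin-1-yl in place of 4-methylpiperidin-1-yl on a thiocarbonyl carbon. Among the compounds with values here, no pair of measured compounds differs in exactly this way, so the expectation rests only on the two known values. Within the data shown here, compound 1 is the only other compound known, and it stands lower than compound 2 in this assay, which leaves room for a drop. A downward step of moderate size is expected a number 15.4 percentage points lower from compound 2 to compound 3 (beyond the scatter). Compound 3 is expected to give about 72% in this assay, within a range from 50% to 90%.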

Compound 3, a percentage reported as inhibition, at one concentration (the size of the read-out at that concentration, not a potency): 91.6%
The estimate for compound 3 lay 19.6 percentage points below the measured number; measured number outside the range, above it.
By their numbers in this assay, from the lowest: compound 1; then compounds 2 and 3 (each within the scatter of the next).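

In this assay, 4-methylpiperazin-1-yl in place of 4-methylpiperidin-1-yl on a thiocarbonyl carbon gives a number 4.2 percentage points higher from compound 2 to compound 3 (within the scatter), so this read-out does not separate the two groups, and the second ring nitrogen costs nothing measurable here. Methyl in place of 4-cyanophenyl on an amine nitrogen in a ring gives a number 28.7 percentage points higher from compound 1 to compound 3 (beyond the scatter), so the lower number of compound 1 goes with its 4-cyanophenyl group and not with the second ring nitrogen as such. Nothing available explains why either step comes out as it does.

Open, from the compounds shown here alone, is how an ethyl or acetyl group on that ring nitrogen would read, and whether a morpholine ring would fit the same place. A reading at one concentration also leaves open how the potencies of compound 2 and compound 3 compare.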